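Shifting the Pyrazole Attachment Point: Compound 3 to Compound 4

This account rests on a few compounds, and the source may have more. Where it says the series, first, only, none or still open, it means among the compounds named here.

Three measured compounds share one core and differ in a single group. Compound 1 `CNC(=O)N1CCCc2ccc(NC(=O)c3cccc(-c4ccccc4)c3)cc21` gives 2.83% in a functional assay on MV4-11 cells (Homo sapiens) for antiproliferative activity, with a stated time of 6 days, tested at 1.56 uM; on this read-out higher numbers stand for a stronger effect at the one concentration tested and lower numbers for a weaker effect. Compound 2 `CNC(=O)N1CCCc2ccc(NC(=O)c3cccc(-c4cnn(C)c4)c3)cc21` gives 71.2%, and compound 3 `CNC(=O)N1CCCc2ccc(NC(=O)c3cccc(-c4cn[nH]c4)c3)cc21` gives 27.9%, the second highest of the three numbers. The step of a number 25.1 percentage points higher from compound 1 to compound 3 (beyond the scatter) shows what placing 1H-pyrazol-4-yl in place of phenyl does, and the step of a number 43.3 percentage points lower from compound 2 to compound 3 (beyond the scatter) shows the effect of hydrogen in place of methyl on an aromatic nitrogen. Compound 4 `CNC(=O)N1CCCc2ccc(NC(=O)c3cccc(-c4cc[nH]n4)c3)cc21` has the same atoms as compound 3, joined differently: 1H-pyrazol-3-yl in place of 1H-pyrazol-4-yl on an aromatic carbon. For the measured compounds named here, no measured step changes only the point at which the five-membered ring is joined, so the two steps reaching compound 3 give the scale of what such a ring can do without fixing a direction. A step of modest size, in either direction, is expected, a number 2.1 percentage points higher from compound 3 to compound 4 (within the scatter). Compound 4 is therefore expected to give 30%, within a range from 5% to 60%.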

Compound 4, a percentage reported as inhibition, at one concentration (the size of the read-out at that concentration, not a potency): 27.3%
Compound 4: the middle estimate sits 2.7 percentage points above what was measured; the range from low to high includes it.
By their numbers in this assay, from the lowest: compound 1; then compounds 4 and 3 (each within the scatter of the next); then compound 2.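

Swapping 1H-pyrazol-4-yl for 1H-pyrazol-3-yl gives a number 0.6 percentage points lower from compound 3 to compound 4 (within the scatter) in this assay, so at this position, meta to a large group, the read-out does not tell the two attachment points apart. The other steps fit this picture: a number 24.5 percentage points higher from compound 1 to compound 4 (beyond the scatter) is close in size to the gain seen with compound 3, while a number 43.9 percentage points lower from compound 2 to compound 4 (beyond the scatter) changes both the methyl and the attachment point, so it cannot be credited to either change alone. Nothing available explains why the two attachment points read alike.

For the compounds shown here, it remains open whether a methyl on a nitrogen of the 1H-pyrazol-3-yl ring would bring a gain like the one separating compound 3 from compound 2. On these data alone, how an ethyl group on that nitrogen, or a six-membered pyridine ring in place of the pyrazole, would read is also open.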